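Acetylation of an Aromatic Amine on Two Different Cores

The source may hold more compounds than are shown below. What is called first, only, known or untested is meant among the compounds shown, and "the series" means these compounds.

Compound 1 `Nc1n[nH]c2cc(-c3cn([C@@H]4CN[C@H](C(=O)Nc5ccc(Cl)cc5Cl)C4)nn3)ccc12` and compound 2 `CC(=O)Nc1n[nH]c2cc(-c3cn([C@@H]4CN[C@H](C(=O)Nc5ccc(Cl)cc5Cl)C4)nn3)ccc12` share one core; compound 3 `Nc1nc2ccc(-c3cn([C@@H]4CN[C@H](C(=O)Nc5ccc(F)c(F)c5)C4)nn3)nc2s1` and compound 4 `CC(=O)Nc1nc2ccc(-c3cn([C@@H]4CN[C@H](C(=O)Nc5ccc(F)c(F)c5)C4)nn3)nc2s1` share another, and the difference between the two cores is not broken down here. In a functional assay on K562 cells (Homo sapiens) for inhibition, read by MTT assay, with a stated time of 48 h (a higher number here means a weaker inhibitor, a lower number a stronger inhibitor), compound 1 gives 28400 nM, while compound 2 gives 2090 nM. The change between them, (acetyl in place of hydrogen on a nitrogen on an aromatic ring), produced a step of a 14-fold lower number from compound 1 to compound 2 (1.13 log units; beyond the scatter). Compound 3 gives 33200 nM in this assay; its value and that of compound 1 lie within the usual scatter of each other. Compound 4 carries the same change on the second core, (acetyl in place of hydrogen on a nitrogen on an aromatic ring), at a place described in identical words. The expected step is a 9.5-fold lower number from compound 3 to compound 4 (0.98 log units; beyond the scatter), resting on a 14-fold lower number from compound 1 to compound 2 (1.13 log units; beyond the scatter), which has been seen only once. Compound 4 is therefore estimated at 3500 nM in this assay, with a range from 1200 nM to 12000 nM.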

Compound 4, half-maximal inhibitory concentration: 63000 nM
Estimate against measurement, compound 4: 18-fold (1.26 log units) below; measured number outside the range, above it.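

In this assay the change did not carry over from one core to the other: the same change on two cores in this assay, a 14-fold lower number (1.13 log units; beyond the scatter) from compound 1 to compound 2 and a 1.9-fold higher number (0.28 log units; within the scatter) from compound 3 to compound 4, 26-fold (1.41 log units) apart, beyond the scatter of two such steps. On the second core the step, a 1.9-fold higher number from compound 3 to compound 4 (0.28 log units; within the scatter), lies within the usual scatter, so the acetyl makes no readable difference there. The two pairs differ from each other in more than one place, so this shows that the step depends on its structural setting but not which part of the structure decides it, and each step rests on a single pair.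

Going by these compounds, it remains open whether a propanoyl or a methanesulfonyl group on the same nitrogen would follow the first pair or the second. On these data alone, it also remains open whether either step would hold with the halogens of the other pair.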